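Swapping phenyl for benzyl on a sulfonamide nitrogen

This account rests on a few compounds, and the source may have more. Where it says the series, first, only, none or still open, it means among the compounds named here.

Of the compounds shown here, two sharing one core have been measured in an assay for inhibition of methylcytosine dioxygenase TET2 (Homo sapiens), read by mass spectrometry, with stated times of 30 min and 1 h; a higher number here means a weaker inhibitor, a lower number a stronger inhibitor. Compound 1, `Cc1oncc1NS(=O)(=O)c1ccc(F)c2ncc(I)cc12`, gives 2100 nM. Compound 2, `O=S(=O)(Nc1ccccc1)c1ccc(F)c2ncc(I)cc12`, gives 23900 nM, the highest of the two numbers and therefore the weaker of the pair. Among the compounds with values here, the only step measured so far, an 11-fold higher number from compound 1 to compound 2 (1.06 log units; beyond the scatter), shows that exchanging the group on the sulfonamide nitrogen can shift the result a great deal.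

Compound 3, `O=S(=O)(NCc1ccccc1)c1ccc(F)c2ncc(I)cc12`, differs from compound 2 by benzyl in place of phenyl on a sulfonamide nitrogen. Within the data shown here, no measured step changes phenyl into benzyl, so the size and direction of this step cannot be read from the data directly; the step from compound 1 to compound 2 only shows that this position is sensitive. Because an 11-fold higher number from compound 1 to compound 2 (1.06 log units; beyond the scatter) is large, a sizeable movement in either direction is plausible, but nothing points one way. Compound 3 is therefore expected to land near compound 2, with a wide range: 30000 nM, between 7000 nM and 120000 nM, meaning an expected step of a 1.3-fold higher number from compound 2 to compound 3 (0.10 log units; within the scatter) in this assay.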

Compound 3, half-maximal inhibitory concentration: > 200000 nM
Compound 3 was reported as a limit; the forecaster's own chance of this, stated with the estimate: 25%; middle value at least 6.6-fold (0.82 log units) from the limit.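

Going from phenyl, with 6 heavy atoms, to benzyl, with 7, gives an at least 8.3-fold higher number from compound 2 to compound 3 (0.92 log units; beyond the scatter) in this assay, so the group on the sulfonamide nitrogen matters not only through which ring it carries, as the earlier pair showed, but also through how that same aromatic ring is attached. Set against the 5-methyl-1,2-oxazol-4-yl group, benzyl gives an at least 95-fold higher number from compound 1 to compound 3 (1.97 log units; beyond the scatter), which places compound 3 at the weak end of the three compounds. Compound 3 is reported only as a limit: the limit of > 200000 nM in this assay, at which 1 of the 3 values shown sits.

The compounds shown do not tell whether a longer chain on the sulfonamide nitrogen, such as 2-phenylethyl, or a benzyl ring carrying an amine or a carboxylic acid, would bring the number back toward that of compound 2 or compound 1. Nor do they tell whether the 5-methyl-1,2-oxazol-4-yl ring, attached through a methylene link in the way benzyl attaches its ring, would respond as phenyl does.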